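The compounds below may be only part of what the source reports. "The series", "measured", "known", "first", "only" and "open" are said of these compounds alone.

Compound 1, `O=C1CCC(N2C(=O)c3cccc(Nc4ccccc4)c3C2=O)C(=O)N1`, 4%; compound 2, `Cc1ccc(Nc2cccc3c2C(=O)N(C2CCC(=O)NC2=O)C3=O)cc1`, 9%; compound 3, `CC(C)(C)c1ccc(Nc2cccc3c2C(=O)N(C2CCC(=O)NC2=O)C3=O)cc1`, 36%.

In an assay on FRT-Jurkat cells for inhibition of nuclear factor NF-kappa-B complex (Homo sapiens), read by flow cytometry, with a stated time of 24 h, tested at 10 uM (on this read-out higher numbers stand for more inhibition at the one concentration tested (going by the name of the read-out) and lower numbers for less inhibition), compound 3 gives the highest of the three numbers. The two steps that reach it, a number 32 percentage points higher from compound 1 to compound 3 (beyond the scatter) and a number 27 percentage points higher from compound 2 to compound 3 (beyond the scatter), both lie beyond the scatter, while the step of a number 5 percentage points higher from compound 1 to compound 2 (within the scatter) does not. Compound 4, `CC(=O)c1ccc(Nc2cccc3c2C(=O)N(C2CCC(=O)NC2=O)C3=O)cc1`, differs from compound 3 by acetyl in place of tert-butyl on an aromatic carbon. For the measured compounds named here, no measured step swaps tert-butyl for acetyl, so nothing shows this exact change. What is known is that both steps that raised the number brought tert-butyl in; taking it out again is therefore expected to lower the number in this assay, by about a number 21 percentage points lower from compound 3 to compound 4 (beyond the scatter). Compound 4 is estimated at 15%, with a range from 0% to 40%.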

Compound 4, a percentage reported as inhibition, at one concentration (the size of the read-out at that concentration, not a potency): 2%
Compound 4: the middle estimate sits 13 percentage points above what was measured; measured number inside the range.
By their numbers in this assay, from the lowest: compounds 4, 1 and 2 (each within the scatter of the next); then compound 3.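

In this assay, acetyl on this aromatic carbon, para to a large group, does not keep the number that tert-butyl gave (a number 34 percentage points lower from compound 3 to compound 4 (beyond the scatter)). Against the smaller cases, acetyl stays within the scatter (a number 7 percentage points lower from compound 2 to compound 4 (within the scatter); a number 2 percentage points lower from compound 1 to compound 4 (within the scatter)), so among these four compounds only tert-butyl stands apart. Nothing available gives a reason for this difference.

On these data alone, whether tert-butyl is special or other branched groups would serve as well stays open. Isopropyl, cyclohexyl or an amine at this position could help to settle that.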